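Sulfanyl to sulfonyl on a shared amide scaffold

This account rests on a few compounds, and the source may have more. Where it says the series, first, only, none or still open, it means among the compounds named here.

Of the compounds shown here, three have been measured in a functional assay on LNCaP cells (Homo sapiens) for antiproliferative activity, read by fluorescence and propidium iodide staining, with a stated time of 96 h; a lower number here means a stronger inhibitor, a higher number a weaker inhibitor. Compound 1 `O=C(Nc1cc(C(F)(F)F)ccc1C(F)(F)F)c1ccc(Sc2ccc(O)cc2)cc1` gives 11400 nM. Compound 2 `O=C(Nc1cccc(S(F)(F)(F)(F)F)c1)c1ccc(Sc2ccc(O)cc2)cc1` gives 3320 nM, the lowest of the three numbers. Compound 3 `O=C(Nc1cc(C(F)(F)F)ccc1C(F)(F)F)c1ccc(S(=O)(=O)c2ccc(O)cc2)cc1` gives 23200 nM. How the core of compound 1 differs from the core of compound 2 is not broken down here.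

Compounds 1 and 3 differ in one place: (4-hydroxyphenyl)sulfonyl in place of (4-hydroxyphenyl)sulfanyl on an aromatic carbon. This change produced a 2.0-fold higher number from compound 1 to compound 3 (0.31 log units; beyond the scatter), so replacing the sulfanyl link by the sulfonyl link made compound 3 a weaker inhibitor than compound 1.

Compound 4 `O=C(Nc1cccc(S(F)(F)(F)(F)F)c1)c1ccc(S(=O)(=O)c2ccc(O)cc2)cc1` has not yet been measured. It stands to compound 2 exactly as compound 3 stands to compound 1: (4-hydroxyphenyl)sulfonyl in place of (4-hydroxyphenyl)sulfanyl on an aromatic carbon. The place of the change is the same in both pairs, so this is the same change made on a different core.

For the measured compounds named here, only one earlier instance of this change is available, from compound 1 to compound 3, where it raised the number beyond the usual scatter. With nothing to suggest the second core behaves otherwise, the step from compound 2 to compound 4 in this assay is expected to be about a 2.0-fold higher number from compound 2 to compound 4 (0.30 log units; within the scatter), resting on the step of a 2.0-fold higher number from compound 1 to compound 3 (0.31 log units; beyond the scatter). On that basis compound 4 is estimated at 6600 nM, with a likely range from 3500 nM to 13000 nM.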

Compound 4, half-maximal inhibitory concentration: 3980 nM
The estimate for compound 4 lay 1.7-fold (0.22 log units) above the measured number; the range from low to high includes it.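

On the core of compound 2, putting (4-hydroxyphenyl)sulfonyl in place of (4-hydroxyphenyl)sulfanyl gave, in this assay, a 1.2-fold higher number from compound 2 to compound 4 (0.08 log units; within the scatter), so this measurement does not separate the two compounds. Set beside the same change on the other core, the two steps are no further apart than repeated measurements of this kind can be expected to scatter: the same change on two cores in this assay, a 2.0-fold higher number (0.31 log units; beyond the scatter) from compound 1 to compound 3 and a 1.2-fold higher number (0.08 log units; within the scatter) from compound 2 to compound 4, 1.7-fold (0.23 log units) apart, within the scatter of two such steps. This shows that a single modest step could describe the change on both cores, so what was seen on one core gave a usable guide to the other, but it does not show that the two steps are truly equal, since one lies beyond the scatter and the other within it, and two pairs cannot establish a rule for further cores or explain why the numbers fall where they do.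

All four compounds shown keep the hydroxyl group on the sulfur-linked ring, so it remains open whether the change would behave the same way if an amine or a carboxylic acid stood in its place. The link itself is also seen only as sulfanyl or sulfonyl, which leaves open how a sulfinyl link or a single oxygen atom in that place would compare on either core.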